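Cyclopentyl for Methyl on the Amide of Compound 3

The source may hold more compounds than are shown below. What is called first, only, known or untested is meant among the compounds shown, and "the series" means these compounds.

Three alkyne-linked compounds sharing one core have been tested in an assay on HEK293 cells for positive allosteric modulation of metabotropic glutamate receptor 5 (Homo sapiens), read by FLIPR, with a stated time of 1 h; a higher number here means that more compound is needed for the effect, a lower number that less compound is needed. Compound 1 `COc1ccccc1C#Cc1nc2c(s1)C(=O)NCC2` gives only a limit of the assay, > 10000 nM. Compound 2 `O=C1c2sc(C#Cc3ccccc3)nc2CN1C1CC1` likewise reaches only a limit, > 10000 nM. Compound 3 `CC(=O)N1CCc2nc(C#Cc3ccccc3)sc2C1` stands at a limit as well, > 10000 nM, so compound 3 has no number of its own in this assay. Among the compounds with values here, the whole picture is summed up by the limit of > 10000 nM in this assay, at which 3 of the 3 values shown sit; no step between measured compounds can be sized from it.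

Compound 4 `O=C(C1CCCC1)N1CCc2nc(C#Cc3ccccc3)sc2C1` is not yet measured. It differs from compound 3 in one place: cyclopentyl in place of methyl on a carbonyl carbon. The acetyl thus becomes a cyclopentylcarbonyl. Within the data shown here, no measured step tells how much such a change moves the read-out in this assay; with all three known values at the limit, the most likely outcome for compound 4 is expected to be another limit, with any gain at best small. The step is expected as an at least 1.2-fold lower number from compound 3 to compound 4 (0.09 log units; that floor lies within the scatter). Compound 4 is expected at 8000 nM in this assay, within 2000 nM to 30000 nM.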

Compound 4, half-maximal effective concentration: 19 nM
Estimate against measurement, compound 4: 420-fold (2.62 log units) above; the measured number lies below the stated range.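

In this assay, the substituent on the carbonyl carbon turns out to be a place where the read-out can move, which the earlier compounds could not show: the limit of > 10000 nM in this assay, at which 3 of the 4 values shown sit.

Cyclopentyl in place of methyl there gives an at least 520-fold lower number from compound 3 to compound 4 (2.72 log units; beyond the scatter), and this size is a floor, not a distance between two numbers. Within the data shown here, compound 4 is the first compound here with a number of its own, and the change that brings it adds a five-membered ring of carbon only, with no hydrogen-bond donor or acceptor entering or leaving.

The compounds shown leave open whether the ring itself counts, or whether an open chain such as tert-butyl on the same carbonyl carbon would serve equally. They also leave open how the read-out would respond to a larger ring such as cyclohexyl, or to an amine nitrogen within the ring.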